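From 3,5-dichlorophenyl to 3,5-dimethoxyphenyl on the amide nitrogen

The compounds below may be only part of what the source reports. "The series", "measured", "known", "first", "only" and "open" are said of these compounds alone.

In a functional assay on A549 cells (Homo sapiens) for antiproliferative activity, read by sulforhodamine B assay, with a stated time of 3 days (on this read-out higher numbers stand for weaker inhibition of growth and lower numbers for stronger inhibition of growth), compound 1 (`COc1ccc(NC(=O)c2cccc(Nc3ncc(F)c(Nc4ccc(F)cc4)n3)c2)cc1`) gives 11000 nM, and compound 2 (`O=C(Nc1cc(Cl)cc(Cl)c1)c1cccc(Nc2ncc(F)c(Nc3ccc(F)cc3)n2)c1`) gives 17500 nM. Going by the values given here, these are the only two numbers known so far, and they lie within the scatter of each other, so compound 2 stands level with compound 1.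

The next compound, compound 3 (`COc1cc(NC(=O)c2cccc(Nc3ncc(F)c(Nc4ccc(F)cc4)n3)c2)cc(OC)c1`), keeps the shared core and differs from compound 2 in a single place: 3,5-dimethoxyphenyl in place of 3,5-dichlorophenyl on an amide-type nitrogen. It carries 3,5-dimethoxyphenyl in place of 3,5-dichlorophenyl on an amide-type nitrogen.

Among the compounds with values here, one measured step bears on this change: a 1.6-fold higher number from compound 1 to compound 2 (0.20 log units; within the scatter), with 3,5-dichlorophenyl in place of 4-methoxyphenyl on that same nitrogen. This step lies within the scatter. Within the data shown here, no measured compound yet carries the 3,5-dimethoxyphenyl group, so this single step is a thin guide. On the strength of a 1.6-fold higher number from compound 1 to compound 2 (0.20 log units; within the scatter), no step beyond the scatter is expected in this assay. The expected step is a 1.3-fold lower number from compound 2 to compound 3 (0.13 log units; within the scatter). For compound 3 the estimate is 13000 nM, with an expected range from 5500 nM to 30000 nM.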

Compound 3, concentration for 50% growth inhibition: 13900 nM
The estimate for compound 3 lay 1.1-fold (0.03 log units) below the measured number; measured number inside the range.
By their numbers in this assay, from the lowest: compounds 1, 3 and 2 (each within the scatter of the next).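

In this assay, going by these compounds alone, the step from the chlorine pair to the methoxy pair is a 1.3-fold lower number from compound 2 to compound 3 (0.10 log units; within the scatter), and moving from the single methoxy group of compound 1 to the two of compound 3 gives a 1.3-fold higher number from compound 1 to compound 3 (0.10 log units; within the scatter). With these steps added to the earlier one, three different aryl groups on the amide nitrogen (4-methoxyphenyl, 3,5-dichlorophenyl and 3,5-dimethoxyphenyl) stand level within the scatter, and neither exchanging both chlorines for methoxy groups nor adding a second methoxy group separates the compounds on this read-out. Nothing available explains why these groups stand level.

From the compounds shown here alone, all three compounds carry an aryl group on this nitrogen, so it remains open whether a group of another kind there, such as a carboxylic acid, a dimethylamino chain or a morpholine, would give a step beyond the scatter. The three also share the same core, including the 4-fluorophenyl group on its other amine, so they cannot show whether a change elsewhere would move the number more than any change at this position has.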